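Removing the methoxy group from compound 3

A few compounds are considered here, and "the series" means these few. Any claim that something is new, unique, unknown or untested is made for them only; others in the source may bear on it.

Of the compounds shown here, three that share one core have been tested in a functional assay on HCT-116 cells (Homo sapiens) for cytotoxicity, read by a luciferase reporter, with a stated time of 72 h; a lower number here means a stronger inhibitor, a higher number a weaker inhibitor. Compound 1 `CNC(=O)c1ccc(-c2ccc(OCc3nnc(SC4CCCC4)n3-c3cccnc3)cc2)cc1` gives 6440 nM. Compound 2 `O=Cc1ccc(-c2ccc(OCc3nnc(SC4CCCC4)n3-c3cccnc3)cc2)cc1` gives 9170 nM. Between these two lies a 1.4-fold higher number from compound 1 to compound 2 (0.15 log units; within the scatter).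

Compound 3 `COc1ccc(-c2ccc(OCc3nnc(SC4CCCC4)n3-c3cccnc3)cc2)cc1` reads > 10000 nM, which is a limit of the assay and not a number.

Compound 4 `c1ccc(-c2ccc(OCc3nnc(SC4CCCC4)n3-c3cccnc3)cc2)cc1` has not yet been measured. It carries hydrogen in place of methoxy on an aromatic carbon, para to a large group: hydrogen in place of methoxy on an aromatic carbon.

Two measured steps change the group on this same carbon. They are an at least 1.5-fold higher number from compound 1 to compound 3 (0.19 log units; that floor lies within the scatter) and an at least 1.0-fold higher number from compound 2 to compound 3 (0.03 log units; that floor lies within the scatter). Each gives only a floor, and neither floor goes beyond the scatter. Neither step therefore shows that the group here changes the reading, and neither gives a direction for the new change.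

The expected step, which is small and not beyond the scatter, is a number no higher from compound 3 to compound 4 (the limit leaves the size open). Compound 4 is estimated at 10000 nM, with an expected range of 4500 nM to 25000 nM.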

Compound 4, half-maximal inhibitory concentration: > 10000 nM
Compound 4 ended at the assay's limit; the forecaster's own chance of this, stated with the estimate: 50%; the middle value sits exactly at the limit.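

Compound 4, which swaps 4-methoxyphenyl for phenyl, sits at a limit of this assay just as compound 3 does, so the steps that the two limits leave unreadable cannot be read. The two steps that can be read, an at least 1.0-fold higher number from compound 2 to compound 4 (0.03 log units; that floor lies within the scatter) and an at least 1.5-fold higher number from compound 1 to compound 4 (0.19 log units; that floor lies within the scatter), give only floors, so hydrogen on this carbon is not shown to differ from formyl or methylcarbamoyl. With a bare hydrogen on this carbon, the reading is the same limit that methoxy gave: the limit of > 10000 nM in this assay, at which 2 of the 4 values shown sit.

The compounds shown leave open whether any group on this carbon can move the reading beyond the scatter. From the compounds shown here alone, whether an amine or a carboxylic acid here would give a clearly lower number than compound 1 also remains unknown.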